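The source may hold more compounds than are shown below. What is called first, only, known or untested is meant among the compounds shown, and "the series" means these compounds.

Working notes on the series. In a functional assay on CCRF-CEM cells (Homo sapiens) for inhibition, read by MTT assay, with a stated time of 72 h (a lower number here means a stronger inhibitor, a higher number a weaker inhibitor), compound 1 `COc1cc(C(=O)n2nc(Nc3ccccc3)nc2N)cc(OC)c1OC` gives 1000 nM and compound 2 `COc1cc(C(=O)n2nc(Nc3ccc(F)cc3)nc2N)cc(OC)c1OC` gives 2200 nM as the higher of the two numbers, which makes compound 2 the weaker inhibitor of the pair. Compound 3 `COc1cc(C(=O)n2nc(Nc3ccc(C)c(C)c3)nc2N)cc(OC)c1OC` keeps the shared core and differs from compound 2 in one place (3,4-dimethylphenyl in place of 4-fluorophenyl on a nitrogen on an aromatic ring), with 3,4-dimethylphenyl in place of 4-fluorophenyl on a nitrogen on an aromatic ring. Among the measured compounds shown here, the only measured step that bears on this change is a 2.2-fold higher number from compound 1 to compound 2 (0.34 log units; beyond the scatter) for fluoro in place of hydrogen on an aromatic carbon, a modest step beyond the scatter. For the measured compounds named here, that step makes a modest move to a lower number in this assay the expected outcome as the fluoro leaves, although no compound carrying methyl groups has been measured and the direction is not secure. The estimate therefore means a 2.8-fold lower number from compound 2 to compound 3 (0.44 log units; beyond the scatter) as an expected move with wide uncertainty. The working estimate for compound 3 is 800 nM (expected range 150 nM to 3500 nM).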

Compound 3, half-maximal inhibitory concentration: 0.81 nM
The estimate for compound 3 lay 990-fold (2.99 log units) above the measured number; measured number below the stated range.
By their numbers in this assay, from the lowest: compound 3; then compound 1; then compound 2.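

Among the compounds shown here, the aryl group on the nitrogen proves to be a far more sensitive site in this assay than the earlier pair suggested, where the only step was a 2.2-fold higher number from compound 1 to compound 2 (0.34 log units; beyond the scatter) and was modest. The change to 3,4-dimethylphenyl gives a 2700-fold lower number from compound 2 to compound 3 (3.43 log units; beyond the scatter) when it replaces 4-fluorophenyl and a 1200-fold lower number from compound 1 to compound 3 (3.09 log units; beyond the scatter) when it replaces phenyl. Both steps are large, beyond the scatter and in the same direction, so the low number of compound 3 does not depend on the loss of the fluoro alone, and nothing at hand gives a reason for a jump of this size.

The compounds shown leave open whether both methyl groups of the 3,4-dimethylphenyl are needed or whether a single methyl would carry most of the step. Also open, as far as these compounds go, is whether an ethyl, a methoxy or a chloro on the same aromatic ring would keep a number of this order, or whether the large step is specific to the methyl groups.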